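The source may hold more compounds than are shown below. What is called first, only, known or untested is meant among the compounds shown, and "the series" means these compounds.

Compound 1 `Cn1cc(-c2ccc(=O)n(CCOc3ccnc4cc(OCCCCCS)ccc34)n2)cn1`: 640 nM
Compound 2 `Cn1cc(-c2ccc(=O)n(CCOc3ccnc4cc(OCc5ccc(C(=O)Nc6ccccc6N)cc5)ccc34)n2)cn1`: 42 nM

In a functional assay on EBC-1 cells (Homo sapiens) for antiproliferative activity, read by sulforhodamine B assay, with a stated time of 72 h (on this read-out lower numbers stand for stronger inhibition and higher numbers for weaker inhibition), compound 2 gives 42 nM, the lower of the two numbers. The gap up to compound 1 lies beyond the scatter.

Compound 3 `Cn1cc(-c2ccc(=O)n(CCOc3ccnc4cc(OCc5ccc(CCC(=O)Nc6ccccc6N)cc5)ccc34)n2)cn1` keeps the rest of compound 2 and differs at one place, on an aromatic carbon para to a large group: 2-((2-aminophenyl)carbamoyl)ethyl in place of (2-aminophenyl)carbamoyl on an aromatic carbon. There, 2-((2-aminophenyl)carbamoyl)ethyl stands in place of (2-aminophenyl)carbamoyl.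

Within the data shown here, no measured pair shows this change, so the expectation rests on the two values and the structural change alone. A modest move toward weaker inhibition is expected, with the number staying below that of compound 1 at 640 nM. The expected change is a 2.4-fold higher number from compound 2 to compound 3 (0.38 log units; beyond the scatter). The estimate for compound 3 is 100 nM, with an expected range of 30 nM to 350 nM.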

Compound 3, half-maximal inhibitory concentration: 210 nM
For compound 3 the middle estimate is 2.1-fold (0.32 log units) below the measured one; low and high end bracket the measured number.
By their numbers in this assay, from the lowest: compound 2; then compound 3; then compound 1.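

Among these compounds, replacing (2-aminophenyl)carbamoyl with 2-((2-aminophenyl)carbamoyl)ethyl on an aromatic carbon para to a large group gives a 5.0-fold higher number from compound 2 to compound 3 (0.70 log units; beyond the scatter) in this assay and is the first single-place comparison. This position is therefore sensitive to the change, even though the two groups have the same hydrogen-bond donor and acceptor counts, the same aromatic ring and no net charge, and differ in their number of heavy atoms. No measurement on hand accounts for the step.

From the compounds shown here alone, with a single pair, it remains open whether a longer chain, such as 3-((2-aminophenyl)carbamoyl)propyl, would continue in the same direction. Also open, going by these compounds, is how a hydroxamic acid or a carboxylic acid would compare with the (2-aminophenyl)carbamoyl group at this position.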